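Truncation of the benzyl substituent in the aminopyrazolyl series

The source may report more compounds than this note shows. Statements on the series, on what has been measured and on what is new or still open speak of the compounds shown alone.

Three compounds of the shared core have numbers in an assay on isolated protein for inhibition of Myeloperoxidase (Homo sapiens), with a stated time of 10 min; on this read-out lower numbers stand for stronger inhibition and higher numbers for weaker inhibition. Compound 1 `Nc1cc(Cc2ccn(-c3cccc(-c4ccccc4)c3)n2)c2nn[nH]c2n1` gives 85 nM. Compound 2 `Nc1cc(Cc2ccn(Cc3cccc(Oc4cccc5c4CNC5)c3)n2)c2nn[nH]c2n1` gives 26 nM. Compound 3 `Nc1cc(C2CCNCc3cccc(c3)COc3cccc(c3)Cn3cc2cn3)c2nn[nH]c2n1` gives 25 nM. Compound 2 stands second highest of the three; its number and that of compound 3 lie within the scatter of each other, while compound 1 lies beyond the scatter above it.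

Compound 4 `Nc1cc(Cc2ccn(Cc3ccccc3)n2)c2nn[nH]c2n1` has not yet been measured in this assay. Its difference from compound 2 is a hydrogen atom in place of a group of 10 heavy atoms (8 carbon, 1 nitrogen, 1 oxygen; one five-membered non-aromatic ring with 1 hetero atom, one six-membered aromatic ring of carbon only), on an aromatic carbon. Among the measured compounds shown here, no measured pair shows this change, so the expectation rests on the loss of that group alone; a step up of moderate size beyond the scatter, toward a weaker number, is expected from compound 2 to compound 4, namely a 12-fold higher number from compound 2 to compound 4 (1.06 log units; beyond the scatter). Compound 4 is estimated at 300 nM in this assay, with a range from 80 nM to 1500 nM.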

Compound 4, half-maximal inhibitory concentration: 120 nM
For compound 4 the middle estimate is 2.5-fold (0.40 log units) above the measured one, and the stated range covers the measured number.
By their numbers in this assay, from the lowest: compounds 3 and 2 (each within the scatter of the next); then compounds 1 and 4 (each within the scatter of the next).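

In this assay, replacing the group of 10 heavy atoms on the aromatic carbon with hydrogen gives a 4.6-fold higher number from compound 2 to compound 4 (0.66 log units; beyond the scatter), the only comparison shown that differs in one place. This step lies beyond the scatter but is modest, so much of the inhibition remains in compound 4 without that group. Nothing measured explains the step. As far as these compounds go, it remains open which part of the group accounts for the step, and whether a phenoxy group or an aminomethyl group at the same place would recover it.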